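The source may report more compounds than this note shows. Statements on the series, on what has been measured and on what is new or still open speak of the compounds shown alone.

Working notes on the series, read in a functional assay on HT-29 cells (Homo sapiens) for inhibition, read by MTT assay, with a stated time of 72 h; a lower number here means a stronger inhibitor, a higher number a weaker inhibitor. Compound 3 `CCN(CC)CCCn1c(=O)c(=Cc2ccccc2O)s/c1=C1\C(=O)Nc2ccc(C)cc21` gives 8070 nM, the lowest of the two numbers in hand. Compound 2 `CCN(CC)CCCn1c(=O)c(=Cc2ccccc2O)s/c1=C1\C(=O)Nc2ccc(Br)cc21` gives 18100 nM. Compound 1 `CCN(CC)CCCn1c(=O)c(=Cc2cc(OC)c(OC)c(OC)c2)s/c1=C1\C(=O)Nc2ccc(C)cc21` gives > 200000 nM, which is a limit and not a number (the limit of > 200000 nM in this assay, at which 1 of the 3 values shown sits). Two steps are measured: a 2.2-fold lower number from compound 2 to compound 3 (0.35 log units; beyond the scatter), a modest step, and an at least 24-fold lower number from compound 1 to compound 3 (1.39 log units; beyond the scatter), a large step.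

Compound 4 `CCN(CC)CCCn1c(=O)c(=Cc2ccccc2O)s/c1=C1\C(=O)Nc2ccccc21` is not yet measured in this assay. It differs from compound 3 by hydrogen in place of methyl on an aromatic carbon. The change removes the methyl that the step from compound 2 to compound 3 introduced, so that modest step is the one that bears on it; the step from compound 1 to compound 3 concerns a different part of the shared core and does not inform this change. A small step in this assay is therefore expected, with no direction established beyond the scatter; the number may sit slightly higher than that of compound 3 but need not. Compound 4 is expected to give 11000 nM, between 4000 nM and 30000 nM. The expected step is a 1.4-fold higher number from compound 3 to compound 4 (0.13 log units; within the scatter).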

Compound 4, half-maximal inhibitory concentration: > 200000 nM
Compound 4: a limit, no number (the forecaster's own chance of this, stated with the estimate: 10%); middle value at least 18-fold (1.25 log units) away from the limit.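

Compound 4 gives no number in this assay, only a limit: the limit of > 200000 nM in this assay, at which 2 of the 4 values shown sit.

The earlier compounds shown here showed only a modest difference between two substituents on this aromatic carbon, whereas hydrogen in place of methyl gives an at least 24-fold higher number from compound 3 to compound 4 (1.39 log units; beyond the scatter), and hydrogen in place of bromo gives an at least 11-fold higher number from compound 2 to compound 4 (1.04 log units; beyond the scatter). Among the compounds carrying the 2-hydroxyphenyl group, those with a methyl or bromo substituent here, compound 3 and compound 2, give numbers and the one with hydrogen does not, although compound 1 shows that the methyl alone does not ensure a number.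

The compounds shown leave open whether other groups on this aromatic carbon, such as chloro or an amine, also give a number. The cause of the large step also stays open.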